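Dropping the pyrrolidine ring: what to expect

The source may hold more compounds than are shown below. What is called first, only, known or untested is meant among the compounds shown, and "the series" means these compounds.

compound 1 `c1coc(CNc2nc(NCCCN3CCCC3)nc3ccccc23)c1` 35300 nM
compound 2 `Clc1cccc(N2CCN(CCCCNc3nc(NCc4ccco4)c4ccccc4n3)CC2)c1Cl` 3870 nM
compound 3 `COc1ccc(Nc2nc(NCc3ccco3)c3cc(F)ccc3n2)cc1` 11600 nM

All three compounds were tested in a functional assay on DU-145 cells (Homo sapiens) for cytotoxicity, read by MTT assay, with a stated time of 2 days; a higher number here means a weaker inhibitor, a lower number a stronger inhibitor. Among them, compound 1 stands highest; its nearest neighbour, compound 3, lies beyond the scatter from it, and compound 2 lies further still, the lowest of the three. None of these pairs differs in just one place, so no single change is isolated by the measured set.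

Compound 4 `CCCCNc1nc(NCc2ccco2)c2ccccc2n1` is not yet measured. It differs from compound 1 by methyl in place of pyrrolidin-1-yl on a saturated chain carbon, three bonds along the chain from a nitrogen on an aromatic ring. Neither compound 2 nor compound 3 carries a plain butyl chain, so the data give no direct guide. Compound 4 is expected to stay near compound 1, with the step of a 1.3-fold higher number from compound 1 to compound 4 (0.11 log units; within the scatter) expected to be small, within the scatter or a modest move toward a weaker inhibitor. For compound 4 the estimate is 45000 nM, within 14000 nM to 140000 nM.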

Compound 4, half-maximal inhibitory concentration: 4990 nM
The estimate for compound 4 lay 9.0-fold (0.96 log units) above the measured number; measured number below the stated range.
By their numbers in this assay, from the lowest: compounds 2 and 4 (each within the scatter of the next); then compound 3; then compound 1.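

Going by these compounds alone, putting butyl in place of the 3-(pyrrolidin-1-yl)propyl chain gives a 7.1-fold lower number from compound 1 to compound 4 (0.85 log units; beyond the scatter) in this assay, the first single change that the compounds isolate. At this position, the pyrrolidine ring is therefore not needed for activity in this assay, and a plain chain gives a stronger inhibitor than compound 1 does. No measurement shown here accounts for the shift.

The compounds shown leave open whether a longer chain such as hexyl, or a hydroxyl group at the end of the butyl chain, would keep this gain.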